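The compounds below may be only part of what the source reports. "The series", "measured", "known", "first", "only" and "open" are said of these compounds alone.

In a functional assay on the whole organism (Tail) for activation, with Mus musculus as the target, with a stated time of 1 min (a lower number here means that less compound is needed, a higher number that more compound is needed for the effect), compound 2 (`O=C1NC(=O)N(/N=C/c2ccc(-c3ccc(Cl)cc3)o2)C1O`) stands at > 1000 mg/kg, which is a limit and not a number. Compound 1 (`O=C1NC(=O)N(/N=C/c2ccc(-c3ccc(Cl)c(Cl)c3)o2)C1O`) gives 34 mg/kg. Among the measured compounds shown here, the one measured step that bears on the change, an at least 29-fold higher number from compound 1 to compound 2 (1.46 log units; beyond the scatter), is large and beyond the scatter, and it comes with hydrogen in place of chloro on an aromatic carbon. Compound 3 (`CC(=O)Nc1ccc(-c2ccc(/C=N/N3C(=O)NC(=O)C3O)o2)cc1`) has acetamido in place of chloro on an aromatic carbon, para to a large group: acetamido in place of chloro on an aromatic carbon. With that last chloro gone, no recovery towards compound 1 is expected in this assay, and the expected change is a number no higher from compound 2 to compound 3 (the limit leaves the size open), nothing beyond the scatter. Compound 3 is estimated at 1000 mg/kg, with an expected range of 250 mg/kg to 3000 mg/kg.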

Compound 3, dose for half-maximal effect: > 1000 mg/kg
Compound 3 was reported as a limit; the forecaster's own chance of this, stated with the estimate: 60%; the middle value lies on the limit itself.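

Compound 2 and compound 3 both stand at a limit in this assay, so no new step can be read between them: the limit of > 1000 mg/kg in this assay, at which 2 of the 3 values shown sit.

On these data alone, whether acetamido in place of chloro changes the dose needed in this assay stays open, as does how far either compound lies beyond its limit.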